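The source may hold more compounds than are shown below. What is called first, only, known or untested is meant among the compounds shown, and "the series" means these compounds.

Of the compounds shown here, two of a shared core have been measured in an assay on isolated protein for inhibition of Maltase-glucoamylase (Homo sapiens), with a stated time of 15 min; on this read-out lower numbers stand for stronger inhibition and higher numbers for weaker inhibition. Compound 1 `O=C(N/N=C\c1ccccn1)c1ccc(-c2nc3ccccc3s2)cc1` gives 10200 nM in this assay. Compound 2 `O=C(N/N=C/c1ccc([N+](=O)[O-])cc1)c1ccc(-c2nc3ccccc3s2)cc1` gives 26400 nM in this assay, which is the higher of the two numbers; the gap between them is beyond the scatter of repeated measurements, so compound 2 is the weaker of the pair. Compound 3 `O=C(N/N=C/c1ccccc1)c1ccc(-c2nc3ccccc3s2)cc1` has not yet been measured. It differs from compound 2 in one place: hydrogen in place of nitro on an aromatic carbon of a six-membered aromatic ring of carbon only, para to a large group. Going by the values given here, no step between measured compounds shows what this change does. Compound 1 carries no nitro group either and sits at a lower number than compound 2, but it differs from compound 3 elsewhere as well, so it offers only a loose pointer. A modest step downward, toward the number of compound 1 at 10200 nM, is expected for compound 3, and the expected step is a 1.9-fold lower number from compound 2 to compound 3 (0.28 log units; within the scatter). For compound 3 the estimated result in this assay is 14000 nM, with a range from 5000 nM to 40000 nM.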

Compound 3, half-maximal inhibitory concentration: 8050 nM
For compound 3 the middle estimate is 1.7-fold (0.24 log units) above the measured one; low and high end bracket the measured number.
By their numbers in this assay, from the lowest: compounds 3 and 1 (each within the scatter of the next); then compound 2.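

In this assay, going by these compounds alone, the change from 4-nitrophenyl to phenyl gives a 3.3-fold lower number from compound 2 to compound 3 (0.52 log units; beyond the scatter), a step beyond the scatter and the first direct reading of this change: on this aromatic carbon, para to a large group, hydrogen goes with a stronger result than nitro in this pair. The exchange of the six-membered aromatic ring with one hetero atom for the six-membered aromatic ring of carbon only, on the amide-type nitrogen, gives a 1.3-fold lower number from compound 1 to compound 3 (0.10 log units; within the scatter), which lies within the scatter, so this pair shows no readable difference between the two rings. No measurement at hand gives a reason for either step.

Within the data shown here, still open is how other groups on this carbon, such as an amine, a carboxylic acid or a methoxy group, would compare with hydrogen and nitro, as the single step here gives only one comparison at this place. Also open, on these data alone, is whether a nitro group on the ring that carries the hetero atom would go with a similar step, or whether the step seen here holds only on the ring of carbon only.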